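Swapping a hydrazide for an aminooxy chain on a nucleoside

The source may report more compounds than this note shows. Statements on the series, on what has been measured and on what is new or still open speak of the compounds shown alone.

Of the compounds shown here, three sharing one nucleoside core have been measured in an assay on isolated protein for inhibition of S-adenosylmethionine decarboxylase proenzyme (Homo sapiens); a lower number here means a stronger inhibitor, a higher number a weaker inhibitor. Compound 1 `Cc1nc2c(N)ncnc2n1[C@@H]1O[C@H](CN(C)CCC(N)=O)[C@@H](O)[C@H]1O` carries a carbamoylmethyl group on the side chain and gives 400 nM. Compound 2 `Cc1nc2c(N)ncnc2n1[C@@H]1O[C@H](CN(C)CCN)[C@@H](O)[C@H]1O` carries an aminomethyl group in its place and gives 88000 nM. Compound 3 `Cc1nc2c(N)ncnc2n1[C@@H]1O[C@H](CN(C)CC(=O)NN)[C@@H](O)[C@H]1O` carries an aminocarbamoyl group and gives 31000 nM; it stands second highest of the three numbers, nearest to compound 2 and far from compound 1.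

Compound 4 `Cc1nc2c(N)ncnc2n1[C@@H]1O[C@H](CN(C)CCCCON)[C@@H](O)[C@H]1O` is the unmeasured member. It differs from compound 3 by 3-(aminooxy)propyl in place of aminocarbamoyl on a saturated chain carbon bound to an amine nitrogen. The measured steps that bear on this position are a 78-fold higher number from compound 1 to compound 3 (1.89 log units; beyond the scatter) and a 2.8-fold lower number from compound 2 to compound 3 (0.45 log units; beyond the scatter). Both show that what hangs on the saturated chain carbon bound to the amine nitrogen can shift the number strongly, yet neither involves an aminooxy group, so the direction of the new step cannot be read from them. The step to compound 4 is therefore expected to be of uncertain size, a 2.1-fold lower number from compound 3 to compound 4 (0.32 log units; beyond the scatter), with a wide range. Compound 4 is estimated at 15000 nM in this assay, between 1500 nM and 150000 nM.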

Compound 4, half-maximal inhibitory concentration: 5 nM
Beside the measured number, compound 4's estimate is 3000-fold (3.48 log units) above it; measured number below the stated range.
By their numbers in this assay, from the lowest: compound 4; then compound 1; then compound 3; then compound 2.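

Until now this position had shown only that changing the group on the saturated chain carbon bound to the amine nitrogen could move the number, and the best of the earlier side chains still left compound 1 well short of what the 3-(aminooxy)propyl chain reaches in this assay (a 6200-fold lower number from compound 3 to compound 4 (3.79 log units; beyond the scatter)). The gain also holds against the other two side chains (an 18000-fold lower number from compound 2 to compound 4 (4.25 log units; beyond the scatter); an 80-fold lower number from compound 1 to compound 4 (1.90 log units; beyond the scatter)), and since all three steps are beyond the scatter, compound 4 is the strongest inhibitor of the four, showing that the position allows a far lower number than the carbamoyl, amino and aminocarbamoyl ends suggested. Why this chain does so much better stays unexplained, as nothing measured here speaks to a cause.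

Compound 4 differs from the others in both the length of its chain and the aminooxy end, so the two contributions cannot be separated. A plain amine at the end of a chain of the same length, or a shorter or longer chain still ending in aminooxy, would show which of the two carries the gain.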